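Acyloxymethyl phosphonate ester prodrugs: half-life in blood

A few compounds are considered here, and "the series" means these few. Any claim that something is new, unique, unknown or untested is made for them only; others in the source may bear on it.

Measured so far in an ADME assay on blood (Homo sapiens) for pharmacokinetics; a lower number here means that the compound disappears faster, a higher number that the compound lasts longer:
- compound 1 `COC(=O)CCNC(=O)[C@@H]1O[P@](=O)(OCOC(=O)c2ccnn2C)OCC1(C)C`: < 0.16 h, a limit of the assay
- compound 2 `CC(C)(C)C(=O)OCO[P@@]1(=O)OCC(C)(C)[C@H](C(=O)NCCC(=O)OCCS(C)(=O)=O)O1`: < 0.16 h, a limit of the assay

Compound 1 stands at the limit rather than at a number. Compound 2 also sits at the limit, so the two values show no order between them. Going by the values given here, both entries coincide with the limit of < 0.16 h in this assay, at which 2 of the 2 values shown sit, and no single-point step between measured compounds is available in this assay.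

Compound 3 `COC(=O)CCNC(=O)[C@@H]1O[P@](=O)(OCOC(=O)c2ccns2)OCC1(C)C` is the next member to be measured. It differs from compound 1 by 1,2-thiazol-5-yl in place of 1-methyl-1H-pyrazol-5-yl on a carbonyl carbon, leaving the shared core and the remainder of the ester unchanged. Among the compounds with values here, with both measured compounds at the limit, there is no step that would point to a direction for this change. The step expected is a step that the limit leaves unreadable from compound 1 to compound 3, none beyond the usual scatter. Compound 3 is therefore estimated at 0.1 h, with a range from 0.03 h to 0.3 h, and most likely reported as a limit again in this assay.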

Compound 3, half-life: < 0.16 h
Compound 3: no number, only a limit; the forecaster's own chance of this, stated with the estimate: 80%; the middle value lies beyond the limit too.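

In this assay compound 3 gives < 0.16 h, a limit of the assay. No step from compound 1 to compound 3 can be read, because both entries stand at the same limit: the limit of < 0.16 h in this assay, at which 3 of the 3 values shown sit.

The compounds shown leave open how 1,2-thiazol-5-yl and 1-methyl-1H-pyrazol-5-yl on this carbonyl carbon compare in half-life.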